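The compounds below may be only part of what the source reports. "The series", "measured", "known", "first", "only" and "open" are said of these compounds alone.

Measured compounds:
compound 1, `CCCOc1cc(C(F)(F)F)ccc1CNC(=O)C(C)c1ccc(NS(C)(=O)=O)c(F)c1`, 2 nM
compound 2, `CC(C(=O)NCc1ccc(C(F)(F)F)cc1[N+](=O)[O-])c1ccc(NS(C)(=O)=O)c(F)c1`, "not active" (no number reported)

Both compounds were tested in an assay on CHO cells for antagonist activity at transient receptor potential cation channel subfamily V member 1 (Homo sapiens), read by FLIPR; on this read-out lower numbers stand for stronger inhibition and higher numbers for weaker inhibition. Compound 1 gives 2 nM in this assay. Compound 2 is reported in this assay as "not active" (no number reported), so no number is available for it, and it cannot be placed on the same scale as compound 1. Compound 3, `CC(C(=O)NCc1ccc(C(F)(F)F)cc1-c1cccc(F)c1)c1ccc(NS(C)(=O)=O)c(F)c1`, has not yet been tested. It differs from compound 2 in one place: 3-fluorophenyl in place of nitro on an aromatic carbon. For the measured compounds named here, no measured step covers this change, so its size can only be guessed. Since compound 2 is "not active" (no number reported), any measurable activity for compound 3 would be a step toward stronger inhibition, and a large one, well beyond the scatter. Compound 3 is expected to give an inhibition constant of about 30 nM, within a range from 4 nM to 300 nM.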

Compound 3, inhibition constant: 1.9 nM
Estimate against measurement, compound 3: 16-fold (1.20 log units) above; the measured number lies below the stated range.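

In this assay, the aromatic carbon that holds nitro in compound 2, reported as not active, also holds 3-fluorophenyl, with compound 3 at 1.9 nM on the same read-out. Replacing propoxy with 3-fluorophenyl gives a 1.1-fold lower number from compound 1 to compound 3 (0.02 log units; within the scatter), so at this place a six-membered aromatic ring of carbon only and a propoxy chain cannot be told apart, while the step from nitro cannot be read as a number. Nothing measured here accounts for nitro standing apart from these two groups.

On these data alone, whether the same carbon also keeps this level of inhibition with an amine, a carboxylic acid or a longer chain such as butoxy remains open. As far as these compounds go, it is equally open whether plain phenyl, without the fluorine, would match 3-fluorophenyl here.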